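This account rests on a few compounds, and the source may have more. Where it says the series, first, only, none or still open, it means among the compounds named here.

Compound 1 `C[C@@H]1O[C@@H](N2C(=O)/C(=C3\Nc4ccccc4C3=O)c3ccccc32)[C@H](O)[C@H](O)[C@H]1O` stands only at a limit in a functional assay on KYSE-70 cells (Homo sapiens) for antiproliferative activity, read by crystal violet staining, with a stated time of 96 h (on this read-out lower numbers stand for stronger inhibition and higher numbers for weaker inhibition), giving > 25000 nM. Compound 2 `Cc1cc(C)c2c(c1)N([C@H]1O[C@@H](C)[C@H](O)[C@@H](O)[C@H]1O)C(=O)/C2=C1\Nc2ccccc2C1=O` also reaches only a limit in this assay, namely > 12500 nM. Compound 3 `C[C@@H]1O[C@H](N2C(=O)/C(=C3\Nc4ccccc4C3=O)c3ccccc32)[C@H](O)[C@H](O)[C@H]1O` likewise gives only the limit > 12500 nM in this assay. Among the measured compounds shown here, the one single-place step, a step that the two limits leave unreadable from compound 1 to compound 3, rests on (the fact that compounds 1 and 3 differ only in the configuration as drawn), yet with both ends at limits its size cannot be read. Compound 4 `C[C@@H]1O[C@@H](N2C(=O)/C(=C3\Nc4ccc(Cl)cc4C3=O)c3ccccc32)[C@H](O)[C@H](O)[C@H]1O` differs from compound 1 by chloro in place of hydrogen on an aromatic carbon. For the measured compounds named here, no measured step bears on chloro entering at that place, and the measured values supply no number to anchor a direction, so no change beyond the scatter can be foreseen. Compound 4 is therefore expected at about 25000 nM, within 6000 nM to 100000 nM, most probably reported again as a limit. The step of a number no higher from compound 1 to compound 4 (the limit leaves the size open) is expected to stay within the scatter.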

Compound 4, half-maximal inhibitory concentration: 15300 nM
Compound 4: middle estimate off by 1.6-fold (0.21 log units), on the high side, and the stated range covers the measured number.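

In this assay, among the compounds shown here, compound 4 gives 15300 nM, the first number. The other compounds shown give only limits. Chloro in place of hydrogen on this aromatic carbon amounts to an at least 1.6-fold lower number from compound 1 to compound 4 (0.21 log units; that floor lies within the scatter), so the readable part of the change does not yet stand clear of the scatter. The full size of the step stays unreadable because compound 1 stands at a limit: the limit of > 25000 nM in this assay, at which 1 of the 4 values shown sits.

From the compounds shown here alone, whether an amine or a methoxy group at this place would lower the number further remains open. Also open, going by these compounds, is whether chloro would give a readable number on the core of compound 3.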